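The source may report more compounds than this note shows. Statements on the series, on what has been measured and on what is new or still open speak of the compounds shown alone.

Measured so far in an in vitro ADME assay on microsomes (Rattus norvegicus) for metabolic stability; a higher number here means faster removal of the compound, a lower number slower removal:
- compound 1 `O=C(CN(C(=O)c1ccc(-c2ccccn2)cc1)C1CCCCC1)Nc1cc(F)cc(F)c1` gives 15.4 mL.min-1.g-1
- compound 2 `O=C(CN(CC1CC1)C(=O)c1ccc(-c2ccccn2)cc1)Nc1cc(F)cc(F)c1` gives 5 mL.min-1.g-1
- compound 3 `COCC(C)N(CC(=O)Nc1cc(F)cc(F)c1)C(=O)c1ccc(-c2ccccn2)cc1` gives 4.2 mL.min-1.g-1

Compound 3 and compound 2 sit together at the low end of these numbers, within the scatter of each other, and compound 1 stands clearly apart from both. Compound 4 `O=C(CN(C(=O)c1ccc(-c2ccccn2)cc1)C1CCOC1)Nc1cc(F)cc(F)c1` differs from compound 3 by one change, oxolan-3-yl in place of 1-(methoxymethyl)ethyl on the amide-type nitrogen (oxolan-3-yl in place of 1-(methoxymethyl)ethyl on an amide-type nitrogen). All three measured steps sit at that same nitrogen. Replacing cyclohexyl gave modest drops, a 3.1-fold lower number from compound 1 to compound 2 (0.49 log units; beyond the scatter) and a 3.7-fold lower number from compound 1 to compound 3 (0.56 log units; beyond the scatter), while a 1.2-fold lower number from compound 2 to compound 3 (0.08 log units; within the scatter) stayed within the scatter. For the measured compounds named here, no measured compound carries oxolan-3-yl, so the expectation is indirect. It starts from compound 3 at 4.2 mL.min-1.g-1 and takes the small last step as the better guide, so no change beyond the scatter is expected in this assay. The expected change is a 1.1-fold lower number from compound 3 to compound 4 (0.02 log units; within the scatter), which would lie within the scatter. For compound 4 the estimated value is 4 mL.min-1.g-1, with an expected range from 2 mL.min-1.g-1 to 8.5 mL.min-1.g-1.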

Compound 4, intrinsic clearance in microsomes: 3.2 mL.min-1.g-1
For compound 4 the middle estimate is 1.3-fold (0.10 log units) above the measured one, within the range that was stated.
By their numbers in this assay, from the lowest: compounds 4, 3 and 2 (each within the scatter of the next); then compound 1.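

Oxolan-3-yl exchanges an open chain for a five-membered non-aromatic ring at the same count of heavy atoms, and in this assay this gives a 1.3-fold lower number from compound 3 to compound 4 (0.12 log units; within the scatter) on the amide-type nitrogen, so at this position a ring as such does not set a number apart from the chain. The comparison with cyclopropylmethyl, a 1.6-fold lower number from compound 2 to compound 4 (0.19 log units; within the scatter), likewise stays within the scatter, while the comparison with cyclohexyl, a 4.8-fold lower number from compound 1 to compound 4 (0.68 log units; beyond the scatter), is beyond it, leaving compound 1 alone apart from the other three. Nothing available explains these steps.

On these data alone, whether cyclopentyl, a ring of carbon alone, or piperidin-4-yl, a ring holding an amine, would stay with compound 4 or move towards compound 1 remains open. As far as these compounds go, whether these steps would hold on another core also remains open.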